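Amide substituent and solubility in the shared core

This account rests on a few compounds, and the source may have more. Where it says the series, first, only, none or still open, it means among the compounds named here.

Measured so far:
compound 1 `Cc1cc(C)c2cc(C(=O)NC3CCN(C)CC3)[nH]c2c1` — > 10000000 nM in a physicochemical assay for solubility, measured as thermodynamic solubility, with a stated time of 24 h, at pH 6.8; a lower number here means a less soluble compound, a higher number a more soluble compound
compound 2 `Cc1cc(C)c2cc(C(=O)NC3CCOCC3)[nH]c2c1` — 17000 nM in this assay

Within the data shown here, compound 2 holds the only number in this assay. The value of compound 1 is a limit of the assay, not a number. Compound 3 `Cc1cc(C)c2cc(C(=O)NC3CCCCC3O)[nH]c2c1` is not yet measured.

From compound 2 to compound 3 the change is 2-hydroxycyclohexyl in place of oxan-4-yl on an amide-type nitrogen. Among the measured compounds shown here, the single measured step, an at least 580-fold lower number from compound 1 to compound 2 (2.76 log units; beyond the scatter), concerns a different change on the same nitrogen and rests on a limit at one end (the limit of > 10000000 nM in this assay, at which 1 of the 2 values shown sits); it gives a scale for how much this position can move the readout, but no direction for the present change. For compound 3 the expectation is a step of a 1.5-fold higher number from compound 2 to compound 3 (0.17 log units; within the scatter), within or near the scatter. The estimated solubility of compound 3 is therefore 25000 nM, with a range of 8000 nM to 80000 nM.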

Compound 3, solubility: 56000 nM
For compound 3 the middle estimate is 2.2-fold (0.35 log units) below the measured one, and the stated range covers the measured number.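

Among these compounds, with a 3.3-fold higher number from compound 2 to compound 3 (0.52 log units; beyond the scatter), the change from oxan-4-yl to 2-hydroxycyclohexyl on the amide-type nitrogen is the only step in this assay with a number at both ends, so it is the first to give this position a firm size and direction. Neither group carries a net charge, which shows that substituents without net charge on this nitrogen can also differ beyond the scatter. The gap from the 1-methylpiperidin-4-yl group remains much wider, with an at least 170-fold lower number from compound 1 to compound 3 (2.25 log units; beyond the scatter), and its size is bounded by a limit, not fixed by a number: the limit of > 10000000 nM in this assay, at which 1 of the 3 values shown sits.

The compounds shown do not separate the loss of the ring oxygen from the gain of the hydroxyl, for which unsubstituted cyclohexyl would be the reference. On these data alone, how an amine or a carboxylic acid in place of that hydroxyl would read in this assay also stays open.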